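This account rests on a few compounds, and the source may have more. Where it says the series, first, only, none or still open, it means among the compounds named here.

Among the compounds with values here, compound 2 `CC/C=C\C(=O)Nc1cc(Nc2ncc(C#N)c(-c3cn(C)c4ccccc34)n2)c(OC)cc1N(C)CCN(C)C` gives 1360 nM in a functional assay on HepG2 cells (Homo sapiens) for antiproliferative activity, read by MTT assay, with a stated time of 72 h (on this read-out higher numbers stand for weaker inhibition and lower numbers for stronger inhibition), the highest of the two numbers measured so far; compound 1 `C=C(Cl)C(=O)Nc1cc(Nc2ncc(C#N)c(-c3cn(C)c4ccccc34)n2)c(OC)cc1N(C)CCN(C)C` gives 115 nM. Within the data shown here, the only measured step is a 12-fold higher number from compound 1 to compound 2 (1.07 log units; beyond the scatter), which exchanges the group on the carbonyl carbon. Compound 3 `COc1cc(N(C)CCN(C)C)c(NC(=O)/C=C\C(C)C)cc1Nc1ncc(C#N)c(-c2cn(C)c3ccccc23)n1` differs from compound 2 by methyl in place of hydrogen on a saturated chain carbon bound to a double-bonded chain carbon and a saturated chain carbon. Among the measured compounds shown here, no measured step touches a saturated chain carbon of this kind, so none bears directly on the change, and no step beyond the scatter is expected in this assay . Compound 3 is estimated at 1400 nM, range 500 nM to 4000 nM, an expected step of a 1.0-fold higher number from compound 2 to compound 3 (0.01 log units; within the scatter).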

Compound 3, half-maximal inhibitory concentration: 1810 nM
Beside the measured number, compound 3's estimate is 1.3-fold (0.11 log units) below it; the range from low to high includes it.
By their numbers in this assay, from the lowest: compound 1; then compounds 2 and 3 (each within the scatter of the next).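

In this assay, methyl in place of hydrogen on this saturated chain carbon gives a 1.3-fold higher number from compound 2 to compound 3 (0.12 log units; within the scatter), so ethyl and isopropyl are not told apart here. The 3-methylbut-1-en-1-yl amide remains well separated from the 1-chloroethenyl amide, with a 16-fold higher number from compound 1 to compound 3 (1.20 log units; beyond the scatter). No measurement shown here accounts for either step. From the compounds shown here alone, the effect of an amine or a longer chain on this saturated chain carbon stays open. Also open, going by these compounds, is how much of the gap to compound 1 belongs to the chlorine and how much to the chain.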